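Shortening the Alkyl Chain on the Core Nitrogen

This account rests on a few compounds, and the source may have more. Where it says the series, first, only, none or still open, it means among the compounds named here.

Measured so far in an assay on CHO cells for displacement of a labelled ligand from adenosine receptor A3 (Homo sapiens), read by scintillation counting, with a stated time of 3 h; a lower number here means a stronger inhibitor, a higher number a weaker inhibitor:
compound 1, `CCn1c(-c2ccccc2)nc2c(NC3CCCCC3)ncnc21`, gives 707 nM
compound 2, `Cn1c(-c2ccccc2)nc2c(NC3CCCCC3)ncnc21`, gives 2370 nM
compound 3, `CCCn1c(-c2ccccc2)nc2c(NC3CCOC3)ncnc21`, gives 2810 nM

Compounds 1 and 2 differ by hydrogen in place of methyl on a saturated chain carbon bound to an aromatic nitrogen. That step, a 3.4-fold higher number from compound 1 to compound 2 (0.53 log units; beyond the scatter), shows that the shorter chain goes with a weaker inhibitor in this pair. Compound 3 carries a different core; the difference between the core of compound 1 and that of compound 3 is not broken down here, and compound 3 stands near compound 2 in this assay.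

Compound 4, `CCn1c(-c2ccccc2)nc2c(NC3CCOC3)ncnc21`, is not yet measured. It differs from compound 3 by hydrogen in place of methyl on a saturated chain carbon, two bonds along the chain from an aromatic nitrogen. This is the same kind of change as that from compound 1 to compound 2, but the place is not identical: there the carbon is bound to an aromatic nitrogen, here it lies two bonds along the chain from it. For the measured compounds named here, a similar direction is expected, since the only measured step of this kind, a 3.4-fold higher number from compound 1 to compound 2 (0.53 log units; beyond the scatter), made the number higher, though a smaller step is expected for a change set further out. The estimated step is a 1.8-fold higher number from compound 3 to compound 4 (0.25 log units; within the scatter). Compound 4 is therefore expected to give about 5000 nM, likely between 2000 nM and 14000 nM.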

Compound 4, inhibition constant: 1660 nM
Compound 4: middle estimate off by 3.0-fold (0.48 log units), on the high side; the whole stated range lies above it.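

In this assay, going from propyl to ethyl gives a 1.7-fold lower number from compound 3 to compound 4 (0.23 log units; within the scatter), so this shortening has no effect that can be told from the scatter, while with the ethyl chain held fixed, oxolan-3-yl in place of cyclohexyl gives a 2.3-fold higher number from compound 1 to compound 4 (0.37 log units; beyond the scatter). The loss seen on removing a methyl from the chain of compound 1 therefore does not carry over to the second core, and the two steps differ by more than the scatter allows: the same change on two cores in this assay, a 3.4-fold higher number (0.53 log units; beyond the scatter) from compound 1 to compound 2 and a 1.7-fold lower number (0.23 log units; within the scatter) from compound 3 to compound 4, 5.7-fold (0.75 log units) apart, beyond the scatter of two such steps This does not show why they differ, since the steps start from different chains, ethyl to methyl and propyl to ethyl, on cores that also carry different rings, and each rests on a single pair, so no rule for the series follows.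

The compounds shown leave open how a longer chain such as butyl would behave on either core. They also leave open whether an amine at the end of the chain would give a number different from that of the plain alkyl chains.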